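Hydroxymethyl for Methoxy on Two Related Aryl Cores

The compounds below may be only part of what the source reports. "The series", "measured", "known", "first", "only" and "open" are said of these compounds alone.

The series starts from compound 1 `COc1cccc(CCCCCC(=O)N2CCOC2=O)c1`, which in an assay on HEK293 cells for inhibition of N-acylethanolamine-hydrolyzing acid amidase (Rattus norvegicus), read by LC-MS, with a stated time of 30 min (on this read-out higher numbers stand for weaker inhibition and lower numbers for stronger inhibition), gives 16300 nM. Compound 2 `O=C(CCCCCc1cccc(CO)c1)N1CCOC1=O` differs from it by hydroxymethyl in place of methoxy on an aromatic carbon. In this assay compound 2 reaches only the limit > 20000 nM. The resulting step, an at least 1.2-fold higher number from compound 1 to compound 2 (0.08 log units; that floor lies within the scatter), is no more than a floor, because the limit of > 20000 nM in this assay, at which 2 of the 3 values shown sit, caps what the measurement can report. Compound 3 `COc1ccc(CCCCCC(=O)N2CCOC2=O)cc1` is built on a core that differs from the core of compound 1; the difference between the two cores is not broken down here. In this assay compound 3 also reaches only the limit > 20000 nM. Compound 4 `O=C(CCCCCc1ccc(CO)cc1)N1CCOC1=O` is the unmeasured member, related to compound 3 by hydroxymethyl in place of methoxy on an aromatic carbon. For the measured compounds named here, this is the same kind of change as the one from compound 1 to compound 2, but not the same: in compound 2 the entering group sits meta to a large group, whereas in compound 4 it sits para to a large group. For compound 4 the expected step is a step that the limit leaves unreadable from compound 3 to compound 4, an estimate that rests on compound 3 already standing at the limit of > 20000 nM in this assay, at which 2 of the 3 values shown sit, and on the earlier step of an at least 1.2-fold higher number from compound 1 to compound 2 (0.08 log units; that floor lies within the scatter) showing no gain from the same kind of change. Compound 4 is therefore expected to give about 30000 nM in this assay, with a range from 12000 nM to 80000 nM, and most probably again only as a limit.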

Compound 4, half-maximal inhibitory concentration: 190 nM
The estimate for compound 4 lay 160-fold (2.20 log units) above the measured number, outside the stated range (below it).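

In this assay, hydroxymethyl in place of methoxy, para to a large group, gives an at least 100-fold lower number from compound 3 to compound 4 (2.02 log units; beyond the scatter), so on this core the change turns a compound that reads only as a limit into one with a measured number. The same change therefore does not carry over from one core to the other with the same outcome, and the result for compound 1 and compound 2 would not have predicted the result for compound 3 and compound 4: the same change on two cores in this assay, an at least 1.2-fold higher number (0.08 log units; that floor lies within the scatter) from compound 1 to compound 2 and an at least 100-fold lower number (2.02 log units; beyond the scatter) from compound 3 to compound 4, at least 120-fold (2.11 log units) apart, beyond the scatter of two such steps This pair of steps does not show what in the two cores separates the outcomes, and it gives neither step in full, as both are only bounds set by a limit: the limit of > 20000 nM in this assay, at which 2 of the 4 values shown sit.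

The compounds shown leave open whether the large step belongs to hydroxymethyl as such, or whether another group at the same place, such as aminomethyl, hydroxyethyl or a carboxylic acid, would serve as well. They also leave open how the result for compound 4 would change with a shorter or longer chain between the aromatic ring and the carbonyl, as every compound here carries the same chain.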